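Cytotoxicity of Three Benzothiazole Amides in Mouse Macrophages

The source may hold more compounds than are shown below. What is called first, only, known or untested is meant among the compounds shown, and "the series" means these compounds.

This study measures how strongly each compound inhibits the growth of mouse macrophage cells in an ADME assay on RAW264.7 cells (Mus musculus) for cytotoxicity, read by MTT assay, with a stated time of 72 h, tested at 50 ug/mL; on this read-out lower numbers stand for less inhibition and higher numbers for more inhibition at the one concentration tested (going by the name of the read-out). Compound 1 `CN1CCN(C(=O)c2nc3ccccc3s2)CC1` gives 52.1% in this assay. Among the compounds with values here, compound 2 `O=C(c1nc2cc(C(F)(F)F)ccc2s1)N1CCN(c2cnccn2)CC1`, which carries a trifluoromethyl group on the shared core and a pyrazin-2-yl group on the ring amine, gives 28.1%; this is the lower of the two numbers known so far, and the gap to compound 1 lies beyond the usual scatter. Compound 3 `CN1CCN(C(=O)c2nc3cc(C(F)(F)F)ccc3s2)CC1` has not yet been measured. It keeps the trifluoromethyl group of compound 2 but differs from it in one place: methyl in place of pyrazin-2-yl on an amine nitrogen in a ring. This brings the ring amine back to the form found in compound 1. A step upward is expected, and the estimated step of a number 16.9 percentage points higher from compound 2 to compound 3 (beyond the scatter) reflects that compound 1 gives 52.1% with the same methyl group. Compound 3 is therefore estimated at 45%, within a range from 25% to 65%.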

Compound 3, a percentage reported as inhibition, at one concentration (the size of the read-out at that concentration, not a potency): 12.6%
Compound 3: the middle estimate sits 32.4 percentage points above what was measured; the measured number lies below the stated range.
By their numbers in this assay, from the lowest: compound 3; then compound 2; then compound 1.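

In this assay, methyl in place of pyrazin-2-yl on an amine nitrogen in a ring gives a number 15.5 percentage points lower from compound 2 to compound 3 (beyond the scatter), so with trifluoromethyl on the core, the smaller methyl group goes with less inhibition, not more. With methyl kept on that nitrogen, trifluoromethyl in place of hydrogen on an aromatic carbon gives a number 39.5 percentage points lower from compound 1 to compound 3 (beyond the scatter), a large step that shows this aromatic carbon strongly affects the read-out, whereas the change on the ring nitrogen gives a modest step. Nothing measured here explains either step.

The compounds shown leave open whether a chlorine atom or a methoxy group on that aromatic carbon would lower the number as far as trifluoromethyl does. They also leave open where an ethyl or a phenyl group on the ring nitrogen would fall relative to methyl and pyrazin-2-yl.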